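Cyclopentyl Amide on the Pyrazole Scaffold: An Expectation

The source may report more compounds than this note shows. Statements on the series, on what has been measured and on what is new or still open speak of the compounds shown alone.

Two compounds set the frame. Compound 1 `COc1cccc(C(=O)Nc2cc(-c3ccccc3)nn2-c2ccccc2)c1` and compound 2 `O=C(Nc1cc(-c2ccccc2)nn1-c1ccccc1F)c1ccccc1` share the same core and differ elsewhere. In a functional assay on cells for positive allosteric modulation of metabotropic glutamate receptor 5 (Rattus norvegicus), read by calcium flux (a lower number here means that less compound is needed, a higher number that more compound is needed for the effect), compound 1 gives 102 nM, and in this assay compound 2 gives 104 nM. Compound 1 has the lowest of the two numbers, but the number of compound 2 sits within the scatter of it, so the two cannot be told apart.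

The next compound, compound 3 `O=C(Nc1cc(-c2ccccc2)nn1-c1ccccc1)C1CCCC1`, departs from compound 1 in one place: cyclopentyl in place of 3-methoxyphenyl on a carbonyl carbon. Within the data shown here, no measured pair shows what such a change does, so nothing about its size can be read from steps already made.

The author therefore expects the step from compound 1 to compound 3 in this assay to go toward a higher number and to reach beyond the scatter, as a 2.9-fold higher number from compound 1 to compound 3 (0.47 log units; beyond the scatter). For compound 3 the author estimates 300 nM in this assay, with a range from 100 nM to 1500 nM.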

Compound 3, half-maximal effective concentration: 3410 nM
The estimate for compound 3 lay 11-fold (1.06 log units) below the measured number, and the stated range ends below it.
By their numbers in this assay, from the lowest: compounds 1 and 2 (each within the scatter of the next); then compound 3.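

Among these compounds, the step from 3-methoxyphenyl to cyclopentyl on a carbonyl carbon is the first single-place change, and in this assay it gives a 33-fold higher number from compound 1 to compound 3 (1.52 log units; beyond the scatter), so this position is far from indifferent to the group it carries. The change alters several things at once: the group that leaves has a six-membered aromatic ring of carbon only and one hydrogen-bond acceptor, while the group that enters has a five-membered non-aromatic ring of carbon only, no hydrogen-bond acceptor and fewer heavy atoms. No available evidence bears on which of these differences accounts for the higher number.

The compounds shown leave open whether a cyclohexyl, which would restore the six-membered ring without aromaticity, or a 3-methoxycyclohexyl, which would also restore the oxygen, stays near compound 1 or near compound 3 in this assay. They also leave open whether a cyclopentyl on the carbonyl carbon of the core of compound 2 would raise the number as strongly as it does here.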